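Sulfonyl substituent change in the NAMPT urea series

A few compounds are considered here, and "the series" means these few. Any claim that something is new, unique, unknown or untested is made for them only; others in the source may bear on it.

Compound 3 `CCCn1cc(S(=O)(=O)c2ccc(CNC(=O)N3Cc4ccncc4C3)cc2)cn1` gives 17 nM in an assay on isolated protein for inhibition of Nicotinamide phosphoribosyltransferase (Homo sapiens), read by mass spectrometry, with stated times of 15 min and 30 min; on this read-out higher numbers stand for weaker inhibition and lower numbers for stronger inhibition. Of the two numbers shown in this assay it stands lowest; compound 1 `O=C(NCc1ccc(S(=O)(=O)c2ccccc2)cc1)NCc1cccnc1` gives 19 nM, a value within the scatter of compound 3, so no order between the two can be read. Compound 2 `O=S(=O)(c1ccccc1)c1ccc(CNS(=O)(=O)N2Cc3ccncc3C2)cc1` gives only a limit in this assay, > 2000 nM, and not a number; the evidence on this point is the limit of > 2000 nM in this assay, at which 1 of the 3 values shown sits.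

Compound 4 `O=C(NCc1ccc(S(=O)(=O)N2CCOCC2)cc1)N1Cc2ccncc2C1` is not yet measured. It differs from compound 3 in one place: morpholin-4-yl in place of 1-propyl-1H-pyrazol-4-yl on a sulfonyl sulfur. Within the data shown here, no measured pair in the set shares this kind of change, so its effect has to be guessed from the two numbers and the one limit alone. Going by these compounds, compound 1 and compound 3 show that two different groups on the sulfonyl sulfur give values within the scatter of each other, but both are ring systems of a kind that compound 4 no longer carries; a non-aromatic ring is untested here.

The expectation for compound 4 is a moderate loss, with the step from compound 3 estimated as a 5.9-fold higher number from compound 3 to compound 4 (0.77 log units; beyond the scatter). Compound 4 is expected to give about 100 nM in this assay, with a likely range from 25 nM to 500 nM.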

Compound 4, half-maximal inhibitory concentration: 71 nM
The estimate for compound 4 lay 1.4-fold (0.15 log units) above the measured number; the range from low to high includes it.
By their numbers in this assay, from the lowest: compounds 3 and 1 (each within the scatter of the next); then compound 4. At a limit, above all of these: compound 2.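

Up to this point, the groups read on the sulfonyl sulfur were all aromatic rings, and compound 4 adds the first non-aromatic one. In this assay, morpholin-4-yl in place of 1-propyl-1H-pyrazol-4-yl gives a 4.2-fold higher number from compound 3 to compound 4 (0.62 log units; beyond the scatter), so this position is not indifferent to the group it carries, although the step is modest and compound 4 keeps a measurable value of 71 nM in the same assay. No measurement shown bears on the cause of this step.

Among these compounds, the single change in compound 4 swaps the ring size, the aromatic character, the atom joined to the sulfur and the propyl chain all at once, so the step cannot be assigned to any one of these. Going by these compounds, how a piperidine ring, an open-chain dimethylamino group or a pyrazole carrying a methyl group in place of the propyl chain would read on the same sulfonyl sulfur remains open, and any of these would help to separate those contributions.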